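The source may report more compounds than this note shows. Statements on the series, on what has been measured and on what is new or still open speak of the compounds shown alone.

Measured compounds:

Compound 1, `C=C1C(=O)O[C@]2(C)CC[C@@H]1C[C@H](O)[C@@]1(C)CC[C@H](O1)[C@](C)(O)CC[C@H]2OC(C)=O`, gives only a limit of > 20 ug/mL in a functional assay on HeLa cells (Homo sapiens) for cytotoxicity; a higher number here means a weaker inhibitor, a lower number a stronger inhibitor.

Compound 2, `C=C1C(=O)O[C@]2(C)CC[C@@H]1C[C@H](O)[C@@]1(C)CC[C@H](O1)[C@](C)(O)CC[C@H]2O`, gives only a limit of > 20 ug/mL in this assay.

Compound 3, `C=C1C(=O)O[C@]2(C)CC[C@@H]1C[C@H](O)[C@@]1(C)CC[C@H](O1)C(=C)CC[C@H]2OC(C)=O`, gives only a limit of > 20 ug/mL in this assay.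

Compound 1 and compound 2 share one core and differ in a single place: acetyl in place of hydrogen on an oxygen on a saturated carbon. The step that the two limits leave unreadable from compound 2 to compound 1 cannot be read, since both of its ends are limits rather than numbers. Compound 3 carries a second core; the difference between the two cores is not broken down here. What compound 3 and compound 2 show is only that each sits at the same limit. The unmeasured compound 4, `C=C1C(=O)O[C@]2(C)CC[C@@H]1C[C@H](OC(C)=O)[C@@]1(C)CC[C@H](O1)C(=C)CC[C@H]2OC(C)=O`, is made from compound 3 by the same change: acetyl in place of hydrogen on an oxygen on a saturated carbon. The place where the change is made is the same in both pairs, so this is the same change, not merely the same kind.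

The expectation for compound 4 rests on (the limit of > 20 ug/mL in this assay, at which 3 of the 3 values shown sit), which holds every value seen in this assay. Because the step that the two limits leave unreadable from compound 2 to compound 1 left both partners at that limit, the step that the limit leaves unreadable from compound 3 to compound 4 is expected to be small, and compound 4 is estimated to sit at or beyond the limit as well. Compound 4 is expected to give about 40 ug/mL, between 15 ug/mL and 150 ug/mL.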

Compound 4, half-maximal inhibitory concentration: > 20 ug/mL
Compound 4: a limit, no number; the forecaster's own chance of this, stated with the estimate: 85%; the middle value is on the limit's open side.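

Compound 4 gives > 20 ug/mL in this assay, which is a limit and not a number. Among the compounds shown here, compound 3 also stands at a limit, so the step from compound 3 to compound 4 cannot be read, and no new step comes from this result. The compounds shown leave open what number any of them would give, and whether putting acetyl in place of hydrogen changes anything in this assay.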